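A Protecting Chain Removed: From Compound 3 to Compound 4

The compounds below may be only part of what the source reports. "The series", "measured", "known", "first", "only" and "open" are said of these compounds alone.

Measured so far in an assay on 32D cells for inhibition of interleukin-15 (Mus musculus), read by resazurin assay, with stated times of 30 min and 2.5 days, in the presence of a further agent that is not named here; a lower number here means a stronger inhibitor, a higher number a weaker inhibitor:
compound 1 `Cn1nc(Cc2nnc(SCCCCCCCC(=O)Nc3ccc(Cl)cc3Cl)n2CCCO[Si](C)(C)C(C)(C)C)c2ccccc2c1=O` — > 30000 nM
compound 2 `Cn1c(Cc2nn(CCC(=O)O)c(=O)c3ccccc23)nnc1SCC(=O)Nc1ccc(Cl)cc1Cl` — > 30000 nM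
compound 3 `Cn1c(Cc2nn(CCCO[Si](C)(C)C(C)(C)C)c(=O)c3ccccc23)nnc1SCCCCCCCC(=O)Nc1ccc(Cl)cc1Cl` — > 30000 nM

Each of these values is a limit of the assay and not a number. For compound 1 the reading > 30000 nM is such a limit. For compound 2 the reading > 30000 nM is likewise a limit. For compound 3 the reading > 30000 nM is a limit as well. All three readings sit at the limit of > 30000 nM in this assay, at which 3 of the 3 values shown sit, so compound 3 cannot be placed against the other two: nothing in this assay separates any of them.

Compound 4 `Cn1c(Cc2n[nH]c(=O)c3ccccc23)nnc1SCCCCCCCC(=O)Nc1ccc(Cl)cc1Cl` differs from compound 3 in a single place: a hydrogen atom in place of a group of 11 heavy atoms (9 carbon, 1 oxygen, 1 silicon; no ring), on an aromatic nitrogen, in words a hydrogen atom in place of a group of 11 heavy atoms (9 carbon, 1 oxygen, 1 silicon; no ring), on an aromatic nitrogen. Going by the values given here, no step between measured compounds exists to guide the direction, since every measured value is a limit. Compound 4 is therefore expected to stay at the same limit in this assay, and the step of a number no higher from compound 3 to compound 4 (the limit leaves the size open) is expected to be none beyond the scatter. The estimate for compound 4 is 30000 nM, with a range from 10000 nM to 100000 nM.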

Compound 4, half-maximal inhibitory concentration: > 30000 nM
Compound 4 gave a limit, no number; the forecaster's own chance of this, stated with the estimate: 85%; the middle value lies on the limit itself.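

In this assay compound 4 gives > 30000 nM as a limit of the assay and not a number. Compound 3 also stands at a limit, so no step can be read between compound 3 and compound 4: the limit of > 30000 nM in this assay, at which 4 of the 4 values shown sit.

The compounds shown leave open whether a hydrogen atom in place of the group of 11 heavy atoms changes inhibition at all, since none of them yields a readable number.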